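Working notes: methyl in place of tert-butyl on compound 3

The compounds below may be only part of what the source reports. "The series", "measured", "known", "first", "only" and "open" are said of these compounds alone.

Values in a functional assay on HUVEC cells (Homo sapiens) for inhibition, with a stated time of 4 days; on this read-out lower numbers stand for stronger inhibition and higher numbers for weaker inhibition:
- compound 1 `Cc1cc(OCc2cccc(C#N)c2)ccc1Cl`: 11000 nM
- compound 2 `COc1ccc(C#N)cc1COc1ccc(Cl)c(C)c1`: 1500 nM
- compound 3 `COc1ccc(C(N)=O)cc1/C=C/c1ccc(C(C)(C)C)cc1`: 370 nM

Compound 3 at 370 nM stands lowest of the three in this assay, with compound 2 at 1500 nM nearest and compound 1 at 11000 nM furthest. Both gaps lie beyond the scatter.

Compound 4 `COc1ccc(C(N)=O)cc1/C=C/c1ccc(C)cc1` has methyl in place of tert-butyl on an aromatic carbon, para to a large group: methyl in place of tert-butyl on an aromatic carbon.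

Going by the values given here, no measured step touches this group. Among the compounds with values here, the only single-place step available is a 7.3-fold lower number from compound 1 to compound 2 (0.87 log units; beyond the scatter), with methoxy in place of hydrogen on an aromatic carbon. It lies beyond the scatter but sits elsewhere on a different core, so it serves only as a gauge of how far one change has moved the number here. The direction is not fixed by the data, but compound 3 at 370 nM already has the lowest number, so a move upward seems the more likely. The expected change is a 2.7-fold higher number from compound 3 to compound 4 (0.43 log units; beyond the scatter), an estimate of modest size. Compound 4 is estimated at 1000 nM, with an expected range from 300 nM to 4000 nM as its bounds.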

Compound 4, half-maximal inhibitory concentration: 1600 nM
Beside the measured number, compound 4's estimate is 1.6-fold (0.20 log units) below it, and the stated range covers the measured number.
By their numbers in this assay, from the lowest: compound 3; then compounds 2 and 4 (each within the scatter of the next); then compound 1.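

In this assay, going by these compounds alone, this is the first measured step at this position: methyl in place of tert-butyl gives a 4.3-fold higher number from compound 3 to compound 4 (0.64 log units; beyond the scatter), so the number here depends on which of these two groups the aromatic carbon carries. As counted, the exchange takes the group from 4 heavy atoms to 1 heavy atom, all carbon, with no ring, hydrogen-bond donor, hydrogen-bond acceptor or net charge on either side. No measurement on hand bears on why the number moves with this change.

Within the data shown here, with only two groups at this position, it remains open whether the number follows the carbon count in a steady way or whether tert-butyl is a special case, and an ethyl, an isopropyl, a chlorine or an amine at the same place would help separate these readings. From the compounds shown here alone, it also remains open whether the same exchange would move the number in the same direction and to a similar extent on the core of compound 1 or compound 2.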